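The compounds below may be only part of what the source reports. "The series", "measured", "known", "first", "only" and "open" are said of these compounds alone.

Compound 1, `C/C(=N\NC(=O)c1cccc(S(=O)(=O)N2CCOCC2)c1)c1cccc(N)c1` — in a functional assay on SMMC-7721 cells (Homo sapiens) for antiproliferative activity, read by MTT assay, with a stated time of 72 h (a lower number here means a stronger inhibitor, a higher number a weaker inhibitor), compound 1 gives only a limit of the assay, > 100000 nM.
Compound 2, `C/C(=N\NC(=O)c1cccc(S(=O)(=O)N2CCOCC2)c1)c1ccccc1O` — in this assay compound 2 gives 1370 nM.
Compound 3, `C/C(=N\NC(=O)c1cccc(S(=O)(=O)N2CCOCC2)c1)c1ccc(O)cc1` — in this assay compound 3 gives 88500 nM.

Among the two numbers that are not limits, compound 3 carries the higher one; its nearest neighbour is compound 2, and the move a 65-fold higher number from compound 2 to compound 3 (1.81 log units; beyond the scatter) is a large step. The pairing of compound 1 with compound 3 shows an at least 1.1-fold lower number from compound 1 to compound 3 (0.05 log units; that floor lies within the scatter), so those two cannot be told apart.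

Compound 4, `C/C(=N\NC(=O)c1cccc(S(=O)(=O)N2CCOCC2)c1)c1cc(O)ccc1O`, differs from compound 3 in one place: 2,5-dihydroxyphenyl in place of 4-hydroxyphenyl on a carbon with a double bond to nitrogen. The new group keeps the hydroxyl that compound 3 already has and brings in a second one at the position that compound 2 carries alone. For the measured compounds named here, two measured steps bear on this. Going from compound 2 to compound 3 removed the 2-hydroxyl and gave a 65-fold higher number from compound 2 to compound 3 (1.81 log units; beyond the scatter); going from compound 1 to compound 2 introduced that same 2-hydroxyl and gave an at least 72-fold lower number from compound 1 to compound 2 (1.86 log units; beyond the scatter). Both point the same way: the 2-hydroxyphenyl pattern goes with a much lower number. Compound 4 is therefore expected to fall well below compound 3, a step of about a 30-fold lower number from compound 3 to compound 4 (1.47 log units; beyond the scatter) in this assay. The estimate for compound 4 is 3000 nM, with a likely range from 800 nM to 15000 nM.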

Compound 4, half-maximal inhibitory concentration: > 100000 nM
Compound 4: no number, only a limit; the forecaster's own chance of this, stated with the estimate: 5%; middle value at least 33-fold (1.52 log units) from the limit.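

A single hydroxy in place of hydrogen on an aromatic carbon turns the 2-hydroxyphenyl of compound 2 into the 2,5-dihydroxyphenyl of compound 4, and in this assay this gives an at least 72-fold higher number from compound 2 to compound 4 (1.86 log units; beyond the scatter). The 2-hydroxyl therefore does not bring a low number on its own, as compounds 1, 2 and 3 seemed to suggest: compound 4 carries it and goes against that pattern, so what else sits on this ring matters too. The comparison with the 4-hydroxyphenyl compound gives an at least 1.1-fold higher number from compound 3 to compound 4 (0.05 log units; that floor lies within the scatter), so these two cannot be told apart, and the step between compound 1 and compound 4 cannot be read because both are limits of the assay: the limit of > 100000 nM in this assay, at which 2 of the 4 values shown sit.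

The compounds shown leave open whether this loss belongs to the added hydroxy itself or would come with any group put in its place on the ring. A methoxy group or a fluorine in place of that hydroxy in compound 4 would separate these two readings.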